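This account rests on a few compounds, and the source may have more. Where it says the series, first, only, none or still open, it means among the compounds named here.

Measured in a functional assay on A549 cells (Homo sapiens) for cytotoxicity, read by MTT assay, with a stated time of 48 h; on this read-out higher numbers stand for weaker inhibition and lower numbers for stronger inhibition:
- compound 1 `COc1ccc(-c2nc3ccccn3c2C(=O)/C=C\Nc2cc(OC)cc(OC)c2)cc1`: 4470 nM
- compound 2 `COc1ccc(-c2nc3ccccn3c2C(=O)/C=C\Nc2ccc3cc[nH]c3c2)cc1`: 8800 nM
- compound 3 `COc1ccc(-c2nc3ccccn3c2C(=O)/C=C\Nc2cnc3ccccc3c2)cc1`: 1050 nM

Compound 1 sits at the high end of these numbers together with compound 2 (a 2.0-fold higher number from compound 1 to compound 2 (0.29 log units; within the scatter)). Compound 3 stands clearly apart from it (a 4.3-fold lower number from compound 1 to compound 3 (0.63 log units; beyond the scatter)).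

The next compound is compound 4 `COc1cc(N/C=C\C(=O)c2c(-c3ccc(Cl)cc3)nc3ccccn23)cc(OC)c1`, which keeps the 3,5-dimethoxyphenyl on the amine nitrogen and changes the other aryl group, 4-methoxyphenyl to 4-chlorophenyl. The change is chloro in place of methoxy on an aromatic carbon, para to a large group.

All measured steps are changes on the amine nitrogen, and the largest is modest (an 8.4-fold lower number from compound 2 to compound 3 (0.92 log units; beyond the scatter)). Among the compounds with values here, the data hold no step at the aromatic carbon that changes here, so these steps show only how far the series has moved at another place. They give no direction for this change. No step beyond the scatter is therefore expected in this assay (estimated a 1.1-fold lower number from compound 1 to compound 4 (0.05 log units; within the scatter)), though a modest move either way remains possible.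

The estimate for compound 4 is an expected value of 4000 nM (expected range 1500 nM to 12000 nM).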

Compound 4, half-maximal inhibitory concentration: 9900 nM
Compound 4: middle estimate off by 2.5-fold (0.39 log units), on the low side, within the range that was stated.
By their numbers in this assay, from the lowest: compound 3; then compounds 1, 2 and 4 (each within the scatter of the next, the first and the last beyond it).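

In this assay, within the data shown here, this is the first step at the aromatic carbon carrying the 4-methoxyphenyl group, and with the 3,5-dimethoxyphenyl kept on the amine nitrogen, chloro in place of methoxy gives a 2.2-fold higher number from compound 1 to compound 4 (0.35 log units; beyond the scatter). The earlier compounds shown here varied only the amine nitrogen substituent, so this shows that the series also responds at this second place: the step lies beyond the scatter, is modest, and runs towards weaker inhibition, with methoxy the better of the two groups here. No measurement in hand accounts for the step, which therefore stands as an observation without an explanation.

The reading rests on one pair, so the compounds shown leave open whether the same step holds with the quinolin-3-yl of compound 3 or the 1H-indol-6-yl of compound 2 on the amine nitrogen. They also leave open how other groups at this aromatic carbon, such as fluoro, hydroxy, an amine or a carboxylic acid, would compare with methoxy and chloro.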